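A few compounds are considered here, and "the series" means these few. Any claim that something is new, unique, unknown or untested is made for them only; others in the source may bear on it.

Within the data shown here, compound 2 `CCC(=O)NC[C@@H]1C[C@H]1c1cccc2c1C[C@@H](CCCCc1ccccc1)O2` stands lowest of the two numbers in an assay on NIH3T3 cells for binding affinity to melatonin receptor type 1B (Homo sapiens) (a higher number here means a weaker inhibitor, a lower number a stronger inhibitor), giving 2 nM; compound 1 `O=C(NC[C@@H]1C[C@H]1c1cccc2c1C[C@@H](CCCCc1ccccc1)O2)C1CC1` gives 5 nM, and the only measured step, a 2.5-fold lower number from compound 1 to compound 2 (0.40 log units; beyond the scatter), altered just the group on the carbonyl carbon. Compound 3 `CCNC(=O)NCCCc1cccc2c1C[C@@H](CCCCc1ccccc1)O2` differs from compound 2 by 3-((ethylcarbamoyl)amino)propyl in place of 2-((propanoylamino)methyl)cyclopropyl on an aromatic carbon. Among the measured compounds shown here, no measured step touches the part of the structure that changes here, so the one step gives little guidance, and the change is larger than it. A modestly higher number is expected for compound 3, estimated at 8 nM with a range of 1.5 nM to 40 nM, which would mean a 4.0-fold higher number from compound 2 to compound 3 (0.60 log units; beyond the scatter).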

Compound 3, inhibition constant: 40 nM
Compound 3: the middle estimate sits 5.0-fold (0.70 log units) below what was measured; the range from low to high includes it.
By their numbers in this assay, from the lowest: compound 2; then compound 1; then compound 3.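

In this assay, 3-((ethylcarbamoyl)amino)propyl in place of 2-((propanoylamino)methyl)cyclopropyl on this aromatic carbon gives a 20-fold higher number from compound 2 to compound 3 (1.30 log units; beyond the scatter), a step larger than the one seen on the carbonyl carbon. The group on this aromatic carbon therefore matters more to the number than the earlier change did. No supporting data explain this step.

The ring and the carbonyl end changed together, so their separate shares remain unresolved. A propyl chain ending in propanoylamino, or a cyclopropyl carrying ethylcarbamoylamino, would separate them.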